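Cyanobenzyl triazole ethers on the shared core: cytotoxicity notes

The compounds below may be only part of what the source reports. "The series", "measured", "known", "first", "only" and "open" are said of these compounds alone.

Compound 1, `N#Cc1ccc(Cn2cc(COc3ccc4c(=O)ccoc4c3)nn2)cc1`, gives > 100000 nM in a functional assay on HeLa cells (Homo sapiens) for cytotoxicity, read by MTT assay, with a stated time of 48 h (a higher number here means a weaker inhibitor, a lower number a stronger inhibitor), which is a limit of the assay and not a number. Compound 2, `O=c1ccoc2cc(OCc3cn(Cc4ccccc4)nn3)ccc12`, gives > 100000 nM in this assay, again a limit. Compound 3, `O=c1ccoc2cc(OCc3cn(Cc4ccc(Br)cc4)nn3)ccc12`, gives > 100000 nM in this assay, also a limit.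

Compound 1 therefore stands at the limit, as do the others: the limit of > 100000 nM in this assay, at which 3 of the 3 values shown sit. The measured steps a step that the two limits leave unreadable from compound 1 to compound 2, a step that the two limits leave unreadable from compound 1 to compound 3 and a step that the two limits leave unreadable from compound 2 to compound 3 are all unreadable, so nothing bears readably on the change to compound 4, `N#Cc1cccc(Cn2cc(COc3ccc4c(=O)ccoc4c3)nn2)c1`: 3-cyanophenyl in place of 4-cyanophenyl on a saturated chain carbon bound to an aromatic nitrogen. No step beyond the scatter is expected, and a step that the limit leaves unreadable from compound 1 to compound 4 is the estimated result. Compound 4 is estimated at 200000 nM, within 60000 nM to 700000 nM, most likely again reported only as a limit.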

Compound 4, half-maximal inhibitory concentration: > 100000 nM
Compound 4 ended at the assay's limit (the forecaster's own chance of this, stated with the estimate: 80%); the middle value lies beyond the limit too.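

Compound 4 gives no readable step against compound 1, compound 2 or compound 3 in this assay, because all four stand at one limit: the limit of > 100000 nM in this assay, at which 4 of the 4 values shown sit.

The compounds shown leave open whether 3-cyanophenyl and 4-cyanophenyl differ in cytotoxicity at all.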